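The source may report more compounds than this note shows. Statements on the series, on what has been measured and on what is new or still open speak of the compounds shown alone.

In a functional assay on HCT-116 cells (Homo sapiens) for antiproliferative activity, with a stated time of 72 h (on this read-out lower numbers stand for stronger inhibition and higher numbers for weaker inhibition), compound 3 `Nc1ncnn2c([C@@H]3O[C@H](CO)[C@@H](O)[C@H]3O)cc(-c3ccccc3)c12` gives 82600 nM, level within the scatter with compound 2 `Nc1ncnn2c([C@@H]3O[C@H](CO)[C@@H](O)[C@H]3O)cc(C#Cc3cccs3)c12` at 65500 nM, as a 1.3-fold higher number from compound 2 to compound 3 (0.10 log units; within the scatter) shows. Compound 1 `Nc1ncnn2c([C@@H]3O[C@H](CO)[C@@H](O)[C@H]3O)cc(C#CC3CC3)c12` stands far apart at 50 nM: a 1700-fold higher number from compound 1 to compound 3 (3.22 log units; beyond the scatter) is large, as is a 1300-fold higher number from compound 1 to compound 2 (3.12 log units; beyond the scatter). Compound 4 `Nc1ncnn2c([C@@H]3O[C@H](CO)[C@@H](O)[C@H]3O)cc(-c3ccc(F)cc3)c12` differs from compound 3 by fluoro in place of hydrogen on an aromatic carbon, which is fluoro in place of hydrogen on an aromatic carbon, turning phenyl into 4-fluorophenyl. For the measured compounds named here, the large steps exchange whole groups, and no measured step tests so small a change. The closest guide is a 1.3-fold higher number from compound 2 to compound 3 (0.10 log units; within the scatter), where a larger exchange stayed within the scatter. The expected change is a 1.1-fold lower number from compound 3 to compound 4 (0.04 log units; within the scatter), with none beyond the scatter anticipated in this assay. Compound 4 is estimated at 75000 nM, with an expected range of 30000 nM to 150000 nM.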

Compound 4, half-maximal inhibitory concentration: 42500 nM
Compound 4: the middle estimate sits 1.8-fold (0.25 log units) above what was measured; the measured number falls inside the stated range.
By their numbers in this assay, from the lowest: compound 1; then compounds 4, 2 and 3 (each within the scatter of the next).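

In this assay, a 1.9-fold lower number from compound 3 to compound 4 (0.29 log units; within the scatter) and a 1.5-fold lower number from compound 2 to compound 4 (0.19 log units; within the scatter) both lie within the scatter, so fluoro on this aromatic carbon, para to a large group, gives no change that can be read. 4-Fluorophenyl also leaves the large gap to the 2-cyclopropylethynyl compound intact, with an 850-fold higher number from compound 1 to compound 4 (2.93 log units; beyond the scatter) beyond the scatter. No evidence on the origin of these differences is available.

Open, going by these compounds, is whether an amine or a carboxylic acid in place of fluoro would shift the number, and whether a longer chain in place of cyclopropyl on the triple-bonded carbon would hold the level of compound 1.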